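Notes on the step from compound 3 to compound 4

The compounds below may be only part of what the source reports. "The series", "measured", "known", "first", "only" and "open" are said of these compounds alone.

Values in a functional assay on NCI-H1975 cells (Homo sapiens) for cytotoxicity, read by MTT assay, with a stated time of 72 h; a higher number here means a weaker inhibitor, a lower number a stronger inhibitor:
- compound 1 `C#Cc1cccc(Nc2nc3cnc(Nc4ccc(N5CCN(C)CC5)cc4)nc3n2C2CCCC2)c1`: 650 nM
- compound 2 `Cc1cccc(Nc2nc3cnc(Nc4ccc(N5CCN(C)CC5)cc4)nc3n2C2CCCC2)c1`: 560 nM
- compound 3 `CN1CCN(c2ccc(Nc3ncc4nc(Nc5cccc(Cl)c5)n(C5CCCC5)c4n3)cc2)CC1`: 390 nM

Compound 3 cannot be separated from the other two compounds, as the steps show: a 1.7-fold lower number from compound 1 to compound 3 (0.22 log units; within the scatter) and a 1.4-fold lower number from compound 2 to compound 3 (0.16 log units; within the scatter). The third measured step, a 1.2-fold lower number from compound 1 to compound 2 (0.06 log units; within the scatter), is equally small.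

Compound 4 `CN1CCN(c2ccc(Nc3ncc4nc(Nc5ccc(Br)cc5)n(C5CCCC5)c4n3)cc2)CC1` is the next to be measured. It differs from compound 3 on a nitrogen on an aromatic ring: 4-bromophenyl in place of 3-chlorophenyl on a nitrogen on an aromatic ring. In words, 4-bromophenyl stands in place of 3-chlorophenyl.

The three measured steps bear on this change only indirectly, as exchanges of methyl, chloro and ethynyl on an aromatic carbon. For the measured compounds named here, none of the measured compounds carries the 4-bromophenyl group, so the data give no direction for this change. No shift beyond the scatter is expected in this assay, and the range is kept wide for the untested group. The expected step is a 1.2-fold higher number from compound 3 to compound 4 (0.06 log units; within the scatter). The estimated value for compound 4 is 450 nM, with an expected range of 180 nM to 1100 nM.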

Compound 4, half-maximal inhibitory concentration: 2090 nM
For compound 4 the middle estimate is 4.6-fold (0.67 log units) below the measured one, outside the stated range (above it).
By their numbers in this assay, from the lowest: compounds 3, 2 and 1 (each within the scatter of the next); then compound 4.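

In this assay, for the compounds shown here, the group on this nitrogen on an aromatic ring is the first place where a change moves the number beyond the scatter: 4-bromophenyl in place of 3-chlorophenyl gives a clear rise (a 5.4-fold higher number from compound 3 to compound 4 (0.73 log units; beyond the scatter)). The same holds against the other two groups, 3-methylphenyl (a 3.7-fold higher number from compound 2 to compound 4 (0.57 log units; beyond the scatter)) and 3-ethynylphenyl (a 3.2-fold higher number from compound 1 to compound 4 (0.51 log units; beyond the scatter)), so the three groups that could not be separated from one another all stand apart from 4-bromophenyl. Nothing available accounts for this rise.

The halogen and its place on the phenyl ring change together in this step, so the compounds shown do not tell which of the two goes with the higher number; 3-bromophenyl and 4-chlorophenyl would separate them. Also open, going by these compounds, is whether other groups, such as 4-methoxyphenyl or 4-aminophenyl, follow 4-bromophenyl.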